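This account rests on a few compounds, and the source may have more. Where it says the series, first, only, none or still open, it means among the compounds named here.

Compound 1 `CS(=O)(=O)Nc1ccc2c(c1)S(=O)(=O)N=C(C1=C(O)C3CCCC3N(CC3CCC3)C1=O)N2` is tested in an ADME assay on Huh-7 cells (Homo sapiens) for cytotoxicity, with a stated time of 72 h; a higher number here means that more compound is tolerated, a lower number that less compound is tolerated. The value for compound 1 there is a limit, > 33000 nM. Compound 2 `CS(=O)(=O)Nc1ccc2c(c1)S(=O)(=O)N=C(C1=C(O)[C@H]3CCC[C@H]3N(CC3CC3)C1=O)N2` also gives a limit in this assay, namely > 33000 nM. Compound 3 `CS(=O)(=O)Nc1ccc2c(c1)S(=O)(=O)N=C(C1=C(O)[C@H]3CCCC[C@H]3N(Cc3ccc(F)cc3)C1=O)N2` gives a limit in this assay as well, > 1000 nM. Going by the values given here, two of the three values sit at the limit of > 33000 nM in this assay, at which 2 of the 3 values shown sit, and one at the limit of > 1000 nM in this assay, at which 1 of the 3 values shown sits, so no measured step between compounds can be compared here. Compound 4 `CS(=O)(=O)Nc1ccc2c(c1)S(=O)(=O)N=C(C1=C(O)C3CCCC3N(Cc3ccccc3)C1=O)N2` is the unmeasured partner, and it differs from compound 1 in one place: phenyl in place of cyclobutyl on a saturated chain carbon bound to an amide-type nitrogen in a ring. With every measured value a limit, a step no larger than the scatter is expected, a number no higher from compound 1 to compound 4 (the limit leaves the size open). Compound 4 is accordingly estimated at 33000 nM in this assay, within a range from 10000 nM to 100000 nM, most likely reported again only as a limit.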

Compound 4, half-maximal cytotoxic concentration: > 33000 nM
Compound 4 ended at the assay's limit; the forecaster's own chance of this, stated with the estimate: 80%; the middle value lies on the limit itself.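

Compound 1 and compound 4 both give only a limit in this assay, so no step can be read between them. The compounds shown leave open what concentration any of them actually tolerates, and whether benzyl differs from cyclobutylmethyl.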